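Compound 3: a ring change at a limit

The source may hold more compounds than are shown below. What is called first, only, known or untested is meant among the compounds shown, and "the series" means these compounds.

Measured in an ADME assay on BaF3 cells (Mus musculus) for antiproliferative activity, read by CellTiter-Glo and CCK-8 assay, with a stated time of 72 h; on this read-out higher numbers stand for weaker inhibition of growth and lower numbers for stronger inhibition of growth:
Compound 1 `CNc1nc(Nc2ccc(C)c([N+](=O)[O-])c2)ncc1C(=O)Nc1cc(NC(=O)c2ccc(OC)cc2)ccc1C`: > 10000 nM (a limit)
Compound 2 `CNc1nc(Nc2ccc(C)c(N)c2)ncc1C(=O)Nc1cc(NC(=O)c2ccc(OC)cc2)ccc1C`: > 10000 nM (a limit)

Compound 2 has no exact number, since its result of > 10000 nM is a limit of the assay. Compound 1 shares that position, and together they make up (the limit of > 10000 nM in this assay, at which 2 of the 2 values shown sit). Neither compound can therefore be ranked against the other.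

Compound 3 `CNc1nc(Nc2ccc(C)c(N)c2)ncc1C(=O)Nc1cc(NC(=O)c2ccc3c(c2)OCCO3)ccc1C` keeps the rest of compound 2 and alters one group: 2,3-dihydro-1,4-benzodioxin-6-yl in place of 4-methoxyphenyl on a carbonyl carbon. In words, 2,3-dihydro-1,4-benzodioxin-6-yl stands in place of 4-methoxyphenyl on a carbonyl carbon.

Among the compounds with values here, only one measured step is available, a step that the two limits leave unreadable from compound 1 to compound 2. It has no readable size, and it concerns a different change, amino in place of nitro. It offers no guide to size or direction here, so no step beyond the scatter is expected in this assay, and the most likely result is another limit. The expected change is a number no higher from compound 2 to compound 3 (the limit leaves the size open). For compound 3 the estimated value is 10000 nM, with an expected range from 3000 nM to 30000 nM.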

Compound 3, concentration for 50% growth inhibition: > 10000 nM
Compound 3 gave a limit, no number (the forecaster's own chance of this, stated with the estimate: 75%); the middle value lies on the limit itself.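

In this assay, compound 2 and compound 3 both give a limit and not a number, so no step can be read between them: the limit of > 10000 nM in this assay, at which 3 of the 3 values shown sit. The compounds shown leave open whether 2,3-dihydro-1,4-benzodioxin-6-yl in place of 4-methoxyphenyl changes growth inhibition at all, and by how much.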